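A few compounds are considered here, and "the series" means these few. Any claim that something is new, unique, unknown or untested is made for them only; others in the source may bear on it.

Measured compounds:
- compound 1 `Fc1ccc(Nc2ccnc(NCCNc3ccnc4cc(Cl)ccc34)n2)cc1`: in an ADME assay on Vero cells (Chlorocebus sabaeus) for cytotoxicity, read by neutral red uptake, with a stated time of 72 h (on this read-out lower numbers stand for stronger inhibition and higher numbers for weaker inhibition), compound 1 gives "not active" (no number reported)
- compound 2 `Clc1ccc(Nc2ccnc(NCCNc3ccnc4cc(Cl)ccc34)n2)cc1`: in this assay compound 2 gives 15800 nM

Going by the values given here, compound 2 thus holds the only number in this assay; compound 1 is recorded without a single number. Compound 3 `Clc1ccc2c(NCCNc3nccc(Nc4ccc(Br)cc4)n3)ccnc2c1` is not yet measured. From compound 2 to compound 3 the change is bromo in place of chloro on an aromatic carbon. Among the compounds with values here, no step between measured compounds is available, so nothing shows how large a shift such a change brings; the expectation is none beyond the scatter. The expected step is a 1.1-fold lower number from compound 2 to compound 3 (0.05 log units; within the scatter). Compound 3 is estimated at 14000 nM, range 5000 nM to 40000 nM.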

Compound 3, half-maximal inhibitory concentration: "not active" (no number reported)
For compound 3 the study gives words and no number; there is nothing to compare the estimate with.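

Going by these compounds alone, compound 3 is recorded in words with no number in this assay, so no step from compound 2 to compound 3 can be read. The compounds shown leave open how far bromo in place of chloro moves the number. No measured evidence bears on this result.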